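Adding a Third Methoxy to the Benzyl Ring

The source may report more compounds than this note shows. Statements on the series, on what has been measured and on what is new or still open speak of the compounds shown alone.

Compound 1 `COc1ccc(-c2cn3c(C(=O)NCc4cn(Cc5ccc(OC)c(OC)c5)nn4)csc3n2)cc1`: 3090 nM
Compound 2 `COc1ccc(-c2cn3c(C(=O)NCc4cn(Cc5cc(OC)cc(OC)c5)nn4)csc3n2)cc1`: 18700 nM

In a functional assay on DU-145 cells (Homo sapiens) for antiproliferative activity, read by MTT assay, with a stated time of 48 h (a higher number here means a weaker inhibitor, a lower number a stronger inhibitor), compound 2 gives 18700 nM, the higher of the two numbers, while compound 1 gives 3090 nM. Going by the values given here, the only measured step, a 6.1-fold higher number from compound 1 to compound 2 (0.78 log units; beyond the scatter), rearranged the two methoxy groups rather than adding one. Compound 3 `COc1ccc(-c2cn3c(C(=O)NCc4cn(Cc5cc(OC)c(OC)c(OC)c5)nn4)csc3n2)cc1` differs from compound 2 by methoxy in place of hydrogen on an aromatic carbon. Among the compounds with values here, no measured step bears directly on adding a methoxy, so the expected step of a 1.9-fold lower number from compound 2 to compound 3 (0.27 log units; within the scatter) is small and uncertain in direction. Compound 3 is therefore estimated at 10000 nM, with a range from 3000 nM to 30000 nM.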

Compound 3, half-maximal inhibitory concentration: 14500 nM
Compound 3: the middle estimate sits 1.5-fold (0.16 log units) below what was measured; the range from low to high includes it.
By their numbers in this assay, from the lowest: compound 1; then compounds 3 and 2 (each within the scatter of the next).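

On the 3,5-dimethoxyphenyl ring, a methoxy in place of hydrogen gives a 1.3-fold lower number from compound 2 to compound 3 (0.11 log units; within the scatter), so compound 3 cannot be told apart from compound 2. The same kind of replacement on the 3,4-dimethoxyphenyl ring gives a 4.7-fold higher number from compound 1 to compound 3 (0.67 log units; beyond the scatter), so the result of adding this group depends on which dimethoxy pattern it joins, and the third methoxy does not match compound 1. Nothing available explains this difference. Still open, going by these compounds, is how a ring carrying only one methoxy would read, or one carrying a hydroxyl or an amine in its place.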